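Side-chain swap from compound 2 to compound 3

This account rests on a few compounds, and the source may have more. Where it says the series, first, only, none or still open, it means among the compounds named here.

Two compounds of the series have been run in a functional assay on the whole organism (Tail, strain ICR) with Mus musculus as the target, in the tail flick test, with a stated time of 90 min, at a dose of 25 umol/kg by the oral route; on this read-out lower numbers stand for a weaker effect and higher numbers for a stronger effect at the one dose given. Compound 1 `O=C(CN(c1ncnc2c1ncn2C1CCCCO1)C1CC1)NCC(=O)OCc1ccccc1` gives 25.9% in this assay. Compound 2 `O=C(O)C[C@H](NC(=O)CN(c1nc(Cl)nc2[nH]cnc12)C1CC1)C(=O)O` gives 25.1% in this assay. Compound 2 holds the lowest of the two numbers, but the nearest one, compound 1, lies within the scatter of it, so no order between the two can be read from this pair; both sit at a low level of effect at the dose given.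

Compound 3 `NCCCC[C@H](NC(=O)CN(c1nc(Cl)nc2[nH]cnc12)C1CC1)C(=O)O` has not yet been measured. It differs from compound 2 in one place: 3-aminopropyl in place of carboxy on a saturated chain carbon, two bonds along the chain from an amide-type nitrogen and a carbonyl carbon. The change thus exchanges one chain end for another of roughly similar size on a saturated chain carbon, two bonds along the chain from an amide-type nitrogen and a carbonyl carbon. Among the measured compounds shown here, no step between measured compounds exists to size such a change against, and compounds 1 and 2 show no movement beyond the scatter between them. The expectation is that the step of a number 2.9 percentage points higher from compound 2 to compound 3 (within the scatter) stays small, in no clear direction, not beyond the scatter. Compound 3 is accordingly estimated at 28%, with a range from 10% to 50%, because compound 2 gives 25.1% and nothing in the series points to a large jump.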

Compound 3, a percentage reported as activity, at one dose (the size of the read-out at that dose, not a potency): 28.8%
For compound 3 the middle estimate is 0.8 percentage points below the measured one; measured number inside the range.
By their numbers in this assay, from the lowest: compounds 2, 1 and 3 (each within the scatter of the next).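

In this assay, among the compounds shown here, the first step that can be sized reads a number 3.7 percentage points higher from compound 2 to compound 3 (within the scatter) on the exchange at the saturated chain carbon, two bonds along the chain from an amide-type nitrogen and a carbonyl carbon. At this place, the read-out at the one dose given does not separate carboxy from 3-aminopropyl, even though the exchange replaces the oxygen-bearing chain end with a longer one that ends in an amine, so this single swap leaves the effect unchanged within the usual spread of repeat measurements. No measured information is at hand to explain this outcome.

The compounds shown leave open whether the same place responds to a chain end carrying neither an amine nor a carboxylic acid, such as a plain butyl chain, a hydroxymethyl group or a phenyl ring. With a single step and a single dose, they also leave open whether this insensitivity holds for other changes on the shared core, and how the two compounds would compare in potency across a range of doses.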